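Terminal sugar deacetylation in an oligosaccharide ester series

This account rests on a few compounds, and the source may have more. Where it says the series, first, only, none or still open, it means among the compounds named here.

Two glycosides of this series have been measured. Compound 1 `CCCCCCCCO[C@@H]1O[C@@H](C)[C@H](OC(=O)CCCCC)[C@@H](O[C@@H]2O[C@@H](C)[C@H](OC(C)=O)[C@@H](O[C@@H]3O[C@@H](C)[C@H](OC(C)=O)[C@@H](OC(C)=O)[C@H]3O)[C@H]2OC(C)=O)[C@H]1O` gives 14.3 ug/mL in a functional assay on KB cells (Homo sapiens) for cytotoxicity; a lower number here means that less compound is needed, a higher number that more compound is needed for the effect. Compound 2 `CCCCCCCCO[C@@H]1O[C@@H](C)[C@H](OC(=O)CCCCC)[C@@H](O[C@@H]2O[C@@H](C)[C@H](OC(C)=O)[C@@H](OC(C)=O)[C@H]2OC(C)=O)[C@H]1O` gives 12.7 ug/mL in this assay. Compound 1 holds the highest of the two numbers, but the gap to compound 2 lies within the usual scatter, so the two are not told apart. For the measured compounds named here, no step between measured compounds is recorded that would show the effect of a single change.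

Compound 3 `CCCCCCCCO[C@@H]1O[C@@H](C)[C@H](OC(=O)CCCCC)[C@@H](O[C@@H]2O[C@@H](C)[C@H](OC(C)=O)[C@@H](O[C@@H]3O[C@@H](C)[C@H](OC(C)=O)[C@@H](O)[C@H]3O)[C@H]2OC(C)=O)[C@H]1O` has not yet been measured. It differs from compound 1 by hydrogen in place of acetyl on an oxygen on a saturated carbon. Going by the values given here, with no comparable step on record, the size of the change cannot be read from the series; the expectation is a step of a 1.2-fold higher number from compound 1 to compound 3 (0.08 log units; within the scatter), small and not clearly beyond the scatter, if anything towards a higher number. For compound 3 the estimated value in this assay is 17 ug/mL, with a range from 8 ug/mL to 34 ug/mL.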

Compound 3, concentration for half-maximal effect: 15.4 ug/mL
Beside the measured number, compound 3's estimate is 1.1-fold (0.04 log units) above it, and the stated range covers the measured number.
By their numbers in this assay, from the lowest: compounds 2, 1 and 3 (each within the scatter of the next).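

For the compounds shown here, compound 1 and compound 3 form the first pair that differs in one place, and acetoxy to hydroxy on an oxygen on a saturated carbon reads as a 1.1-fold higher number from compound 1 to compound 3 (0.03 log units; within the scatter) in this assay for this pair. The two compounds are therefore not told apart, so the acetyl group at this place can be exchanged for hydrogen without a step beyond the scatter, at least in this one pair and this one assay. Nothing on record bears on the reason for this result.

Still open, as far as these compounds go, is whether a benzoyl ester, a methyl ether or an amine at this place would also stay within the scatter of compound 1. Also open, from the compounds shown here alone, is whether the same exchange at the other acetoxy groups of the core would read the same way.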